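The source may report more compounds than this note shows. Statements on the series, on what has been measured and on what is new or still open speak of the compounds shown alone.

Measured compounds in a functional assay on Vero cells (Chlorocebus sabaeus) for cytotoxicity; on this read-out higher numbers stand for lower toxicity in this test and lower numbers for higher toxicity in this test:

Compound 1 `CCCCCCCCOC(=O)C(O)Cn1cnc2c(N)ncnc21` gives 200 ug/mL.
Compound 2 `COCCOC(=O)C(O)Cn1cnc2c(N)ncnc21` gives > 400 ug/mL; this is a limit of the assay, not a number.
Compound 3 `Nc1ncnc2c1ncn2CC(O)C(=O)OCCO` gives > 400 ug/mL; this too is a limit of the assay.

Within the data shown here, compound 1 is the only member of the three with an actual number; the other two values are the limit of > 400 ug/mL in this assay, at which 2 of the 3 values shown sit. The unmeasured compound 4 `CCC(C)OC(=O)C(O)Cn1cnc2c(N)ncnc21` differs from compound 1 in a single place: sec-butyl in place of octyl on an oxygen next to a carbonyl group.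

Among the measured compounds shown here, two measured steps bear on this change, both leaving octyl from the same ester oxygen: an at least 2.0-fold higher number from compound 1 to compound 2 (0.30 log units; that floor lies within the scatter) and an at least 2.0-fold higher number from compound 1 to compound 3 (0.30 log units; that floor lies within the scatter). Between the two limits the step that the two limits leave unreadable from compound 2 to compound 3 cannot be sized. The change to compound 4 is of the same kind, a loss of octyl at the ester oxygen, but what enters is sec-butyl rather than a group carrying an oxygen. The read-out of compound 4 is therefore expected to move upward by about a 2.0-fold higher number from compound 1 to compound 4 (0.30 log units; within the scatter), toward or onto the limit. Compound 4 is estimated at 400 ug/mL, with a range of 200 ug/mL to 800 ug/mL, and a fair chance that only a limit is reported.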

Compound 4, minimum cytotoxic concentration: > 400 ug/mL
Compound 4: only a limit was reported; the forecaster's own chance of this, stated with the estimate: 50%; the middle value sits exactly at the limit.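

In this assay, the change at this ester oxygen now has a step in which the entering group, sec-butyl, carries no oxygen: an at least 2.0-fold higher number from compound 1 to compound 4 (0.30 log units; that floor lies within the scatter). Until now, both steps away from octyl brought in a group carrying an oxygen, so among the compounds shown, reaching the limit does not depend on such an oxygen, although the floor of this step lies within the scatter. The steps among compound 2, compound 3 and compound 4 cannot be read, and the series offers little room for ranking: the limit of > 400 ug/mL in this assay, at which 3 of the 4 values shown sit.

Going by these compounds, it remains open where the read-out in this assay first becomes a number for chains between sec-butyl and octyl, such as hexyl, and how a longer chain such as dodecyl reads. On these data alone, it is equally open how an amine on the ester chain, or a free carboxylic acid in place of the ester, would read.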